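The source may report more compounds than this note shows. Statements on the series, on what has been measured and on what is new or still open speak of the compounds shown alone.

Measured so far:
compound 1, `O=C1O[C@]2(CC[C@H](CNc3ccn(-c4ccccc4F)n3)CC2)CN1c1ccccn1`, 0.0316 nM in a functional assay for antagonist activity at Neuropeptide Y receptor type 5 (Homo sapiens); a lower number here means a stronger inhibitor, a higher number a weaker inhibitor
compound 2, `O=C1O[C@]2(CC[C@H](CNc3cnn(-c4ccccc4F)c3)CC2)CN1c1cncnc1`, 0.0398 nM

Both numbers come from the same assay, and both are very low, which marks both compounds as strong inhibitors. Compound 2 holds the higher of the two numbers, but its gap to compound 1 is within the usual scatter of this assay, so the two cannot be told apart on these values. Among the compounds with values here, compound 1 and compound 2 differ in more than one part of their structures, so no single step between them can be read off.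

Compound 3, `O=C1O[C@]2(CC[C@H](CNc3cnn(-c4ccccc4F)c3)CC2)CN1c1ccnnc1`, has not been measured yet. It differs from compound 2 in one place only: pyridazin-4-yl in place of pyrimidin-5-yl on an amide-type nitrogen in a ring. The group that leaves and the group that enters have the same atoms, joined differently, and both carry the same count of hydrogen-bond acceptors and no donors. Within the data shown here, with no measured step of this kind to lean on, the expectation is a change no larger than the scatter, with no clear direction. The step from compound 2 to compound 3 in this assay is therefore expected to be a 1.3-fold higher number from compound 2 to compound 3 (0.10 log units; within the scatter). Compound 3 is estimated at 0.05 nM, likely between 0.015 nM and 0.16 nM.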

Compound 3, inhibition constant: 0.2 nM
The estimate for compound 3 lay 4.0-fold (0.60 log units) below the measured number; measured number above the stated range.
By their numbers in this assay, from the lowest: compounds 1 and 2 (each within the scatter of the next); then compound 3.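

At the amide-type nitrogen in a ring, pyridazin-4-yl in place of pyrimidin-5-yl gives a 5.0-fold higher number from compound 2 to compound 3 (0.70 log units; beyond the scatter) in this assay, so this position responds even when the group that leaves and the group that enters have the same atoms and the same counts of hydrogen-bond donors and acceptors. Only the way the ring atoms are joined differs, and that alone is enough to move the number beyond the scatter, although compound 3 at 0.2 nM remains a strong inhibitor by the low value of its number. Nothing measured here explains why this rearrangement weakens inhibition, so the step stands as an observation without a cause.

One step cannot show whether the outcome depends on the ring nitrogens in general or on this particular arrangement, and a plain phenyl ring or a pyrazin-2-yl group at the same place would help to separate those two readings. As far as these compounds go, it also remains open whether the same swap would give a step of similar size on the core of compound 1, which differs from compound 2 in more than one place.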